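A Benzofuran Swap on a Methoxy Nucleoside Core

The compounds below may be only part of what the source reports. "The series", "measured", "known", "first", "only" and "open" are said of these compounds alone.

Compound 1, `COc1ncnc2c1c(-c1cccs1)cn2[C@@H]1O[C@H](CO)[C@@H](O)[C@H]1O`, gives 90 nM.
Compound 2, `Cc1ncnc2c1c(-c1cccs1)cn2[C@@H]1O[C@H](CO)[C@@H](O)[C@H]1O`, gives only a limit of the assay, > 20000 nM.
Compound 3, `CNc1ncnc2c1c(-c1cccs1)cn2[C@@H]1O[C@H](CO)[C@@H](O)[C@H]1O`, gives only a limit of the assay, > 20000 nM.

In a functional assay on CCRF-CEM cells (Homo sapiens), read by MTT assay, with a stated time of 72 h (a lower number here means a stronger inhibitor, a higher number a weaker inhibitor), compound 1 is the only one of the three with an actual number; the other two values are limits. The step with methyl in place of methoxy is an at least 220-fold higher number from compound 1 to compound 2 (2.34 log units; beyond the scatter), and the step with methylamino in place of methoxy is an at least 220-fold higher number from compound 1 to compound 3 (2.34 log units; beyond the scatter), both compounds sitting at the limit of > 20000 nM in this assay, at which 2 of the 3 values shown sit. Between them the step is a step that the two limits leave unreadable from compound 2 to compound 3.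

The unmeasured compound 4, `COc1ncnc2c1c(-c1cc3ccccc3o1)cn2[C@@H]1O[C@H](CO)[C@@H](O)[C@H]1O`, keeps the methoxy group of compound 1 and changes only the aryl group: 1-benzofuran-2-yl in place of thiophen-2-yl on an aromatic carbon. Going by the values given here, none of the measured steps touches that position, so they give no direct guidance on its size or direction. With the methoxy group retained, a step within the scatter from compound 1 is expected, a 1.5-fold lower number from compound 1 to compound 4 (0.18 log units; within the scatter). Compound 4 is therefore estimated at 60 nM, within a range of 10 nM to 400 nM.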

Compound 4, half-maximal inhibitory concentration: 5370 nM
Compound 4: the middle estimate sits 90-fold (1.95 log units) below what was measured, and the stated range ends below it.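

This aryl position matters as much as the methoxy group: in this assay, 1-benzofuran-2-yl in place of thiophen-2-yl gives a 60-fold higher number from compound 1 to compound 4 (1.78 log units; beyond the scatter), even though the methoxy group stays. The earlier compounds shown here showed only what happens when the methoxy group is replaced, whereas this change shows that keeping it does not preserve activity once the aryl group changes, although compound 4 still gives a real number and not a limit. Nothing measured here explains the change.

From the compounds shown here alone, the added six-membered ring and the oxygen in place of sulfur arrive together in this one step, so their separate contributions remain unknown. A furan-2-yl group at the same carbon would leave out the added ring and could help to separate the two.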